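Naphthyl to dimethylaminophenoxy: expected cytotoxicity of compound 3

This account rests on a few compounds, and the source may have more. Where it says the series, first, only, none or still open, it means among the compounds named here.

Compound 1 `COc1ccc(F)cc1CNCCCNc1ccnc2cc(C3CCCCC3)ccc12` and compound 2 `COc1ccc(F)cc1CNCCCNc1ccnc2cc(-c3cccc4ccccc34)ccc12` share a core and differ only in one group. In an ADME assay on HepG2 cells (Homo sapiens) for cytotoxicity, read by luminescence, CellTiter-Glo and ATP content, with a stated time of 72 h (a higher number here means that more compound is needed for the effect, a lower number that less compound is needed), compound 1 gives 2290 nM and compound 2 gives 16000 nM. Going by the values given here, the step of a 7.0-fold higher number from compound 1 to compound 2 (0.84 log units; beyond the scatter) is the only measured change, and compound 2 stands highest of the two numbers in this assay, with compound 1 as its nearest neighbour. Compound 3 `COc1ccc(F)cc1CNCCCNc1ccnc2cc(Oc3cccc(N(C)C)c3)ccc12` has not yet been measured; it differs from compound 2 by 3-(dimethylamino)phenoxy in place of naphthalen-1-yl on an aromatic carbon. Among the compounds with values here, no measured step exchanges an aryl group for an aryloxy group, so the expectation rests only on the one change from compound 1 to compound 2, which shows that the group at this position can move the number beyond the scatter. Compound 3 is therefore expected to give a value near 8000 nM in this assay, with a range from 2000 nM to 32000 nM, meaning an expected step of a 2.0-fold lower number from compound 2 to compound 3 (0.30 log units; within the scatter).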

Compound 3, half-maximal effective concentration: 3300 nM
Compound 3: middle estimate off by 2.4-fold (0.38 log units), on the high side, and the stated range covers the measured number.
By their numbers in this assay, from the lowest: compounds 1 and 3 (each within the scatter of the next); then compound 2.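

With 3-(dimethylamino)phenoxy on this aromatic carbon, this assay shows a 4.8-fold lower number from compound 2 to compound 3 (0.69 log units; beyond the scatter), a second step beyond the scatter at this position and the first to involve a group joined through oxygen. The other comparison gives a 1.4-fold higher number from compound 1 to compound 3 (0.16 log units; within the scatter), which is within the scatter, so among the three groups shown only naphthalen-1-yl stands apart, while cyclohexyl and 3-(dimethylamino)phenoxy cannot be told apart here. Nothing available explains these differences. As far as these compounds go, what remains open is whether the step follows the oxygen link, the dimethylamino group or the loss of the second ring, which a plain phenoxy group or a directly joined dimethylaminophenyl group could separate. From the compounds shown here alone, how a carboxylic acid or a longer alkyl chain at this place would read also remains open.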